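The compounds below may be only part of what the source reports. "The series", "measured", "known", "first", "only" and "open" are said of these compounds alone.

Compounds measured in a functional assay on A-375 cells (Homo sapiens) for antiproliferative activity, read by CCK-8 assay, with a stated time of 72 h, tested at 8 uM; a higher number here means a stronger effect of the compound at the concentration tested, a lower number a weaker effect:
compound 1, `Nc1ccccc1NC(=O)c1ccc(CSC(=S)N2CCN(c3ccc(Cl)cc3)CC2)cc1`, gives 29%
compound 2, `Nc1ccccc1NC(=O)c1ccc(CSC(=S)N2CCN(c3cccnc3)CC2)cc1`, gives 88.8%
compound 3, `Nc1ccccc1NC(=O)c1ccc(CSC(=S)N2CCN(Cc3cccnc3)CC2)cc1`, gives 89.2%

Compound 3 holds the highest of the three numbers in this assay, but its gap to compound 2 is within the scatter (a number 0.4 percentage points higher from compound 2 to compound 3 (within the scatter)); only compound 1 lies far off (a number 60.2 percentage points higher from compound 1 to compound 3 (beyond the scatter)).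

Compound 4, `Nc1ccccc1NC(=O)c1ccc(CSC(=S)N2CCN(c3cnccn3)CC2)cc1`, is the next entry. It differs from compound 3 as follows: pyrazin-2-yl in place of (pyridin-3-yl)methyl on an amine nitrogen in a ring.

Two kinds of measured step bear on this. First, a number 0.4 percentage points higher from compound 2 to compound 3 (within the scatter) shows that moving the pyridin-3-yl ring from sitting directly on the ring nitrogen to hanging from it through a methylene changes nothing beyond the scatter. Second, a number 59.8 percentage points higher from compound 1 to compound 2 (beyond the scatter) and a number 60.2 percentage points higher from compound 1 to compound 3 (beyond the scatter) show that exchanging 4-chlorophenyl on that ring nitrogen for either pyridyl group gives a large rise. Compound 4 again carries a six-membered aromatic ring with ring nitrogen directly on the piperazine-type nitrogen, as compound 2 does. For the measured compounds named here, no measured step covers the exchange of pyridin-3-yl for pyrazin-2-yl itself, so that part of the change is untested.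

Given this, the step from compound 3 to compound 4 is expected to stay within the scatter, a number 5.2 percentage points lower from compound 3 to compound 4 (within the scatter). Compound 4 is accordingly estimated at 84% in this assay, with a range from 62% to 95%.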

Compound 4, a percentage reported as inhibition, at one concentration (the size of the read-out at that concentration, not a potency): 85.8%
Beside the measured number, compound 4's estimate is 1.8 percentage points below it; the measured number falls inside the stated range.
By their numbers in this assay, from the lowest: compound 1; then compounds 4, 2 and 3 (each within the scatter of the next).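

In this assay, for the compounds shown here, the exchange of pyridin-3-yl for pyrazin-2-yl, which no earlier step covered, gives a number 3 percentage points lower from compound 2 to compound 4 (within the scatter), and the exchange of (pyridin-3-yl)methyl for pyrazin-2-yl on the same amine nitrogen gives a number 3.4 percentage points lower from compound 3 to compound 4 (within the scatter), so compound 2, compound 3 and compound 4 cannot be told apart at this concentration. The large gap to the 4-chlorophenyl compound now extends to a ring with 2 hetero atoms, with pyrazin-2-yl in place of 4-chlorophenyl giving a number 56.8 percentage points higher from compound 1 to compound 4 (beyond the scatter); among the compounds shown, all three nitrogen-containing aromatic groups sit far from compound 1, whether attached directly or through a methylene, and none goes against this. The data shown offer no measured explanation for either the large gap or the lack of separation among these three groups.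

The compounds shown leave open whether the gap follows from the chlorine or from the phenyl ring itself, which an unsubstituted phenyl or a benzyl group on the same nitrogen would address. Also open, on these data alone, is how far the position accepts other groups, such as pyrimidin-2-yl, a pyridin-3-yl ring on a longer chain, or a saturated ring such as piperidine.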